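Swapping a Heteroaryl Group on a Shared Core

The source may hold more compounds than are shown below. What is called first, only, known or untested is meant among the compounds shown, and "the series" means these compounds.

The series shares one core, on which a single aromatic group varies. Compound 1 `c1cnc(-c2ccccc2OCC2=NCCN2)nc1` carries pyrimidin-2-yl and, in a functional assay with Alpha-1A adrenergic receptor (Homo sapiens) as the target, read by calcium flux (on this read-out higher numbers stand for larger maximal responses and lower numbers for smaller maximal responses), compound 1 gives 90%, the lowest of the three measured numbers. Compound 2 `c1coc(-c2ccccc2OCC2=NCCN2)c1` carries furan-2-yl instead, and in this assay compound 2 reaches 106%. Compound 3 `Cc1ccc(-c2ccccc2OCC2=NCCN2)s1` carries 5-methylthiophen-2-yl, and in this assay compound 3 reaches 97%. The two measured steps away from compound 1 are a number 16 percentage points higher from compound 1 to compound 2 (beyond the scatter) and a number 7 percentage points higher from compound 1 to compound 3 (within the scatter); between the two five-membered rings the step is a number 9 percentage points lower from compound 2 to compound 3 (within the scatter).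

Compound 4 `Cc1cc(-c2ccccc2OCC2=NCCN2)sn1` differs from compound 1 in one place: 3-methyl-1,2-thiazol-5-yl in place of pyrimidin-2-yl on an aromatic carbon. Both measured steps that bear on this change, an exchange of pyrimidin-2-yl for a five-membered aromatic ring, pointed the same way, one beyond the scatter and one within it, the larger being a number 16 percentage points higher from compound 1 to compound 2 (beyond the scatter). Compound 4 is therefore expected to give a small upward step, a number 8 percentage points higher from compound 1 to compound 4 (within the scatter), which may well fall within the scatter. The estimate for compound 4 in this assay is 98%, with a range from 85% to 112%.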

Compound 4, largest response reached (reported as maximum), in percent of the reference or control that the assay uses: 75%
Compound 4: middle estimate off by 23 percentage points, on the high side; the whole stated range lies above it.
By their numbers in this assay, from the lowest: compound 4; then compounds 1, 3 and 2 (each within the scatter of the next, the first and the last beyond it).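

In this assay, replacing pyrimidin-2-yl with 3-methyl-1,2-thiazol-5-yl gives a number 15 percentage points lower from compound 1 to compound 4 (beyond the scatter) and thus a drop at this position, so exchanging the six-membered ring for a five-membered aromatic ring does not by itself raise the number, as the furan-2-yl of compound 2 had suggested. The five-membered rings also differ among themselves, with a number 22 percentage points lower from compound 3 to compound 4 (beyond the scatter) and a number 31 percentage points lower from compound 2 to compound 4 (beyond the scatter) on the change to 3-methyl-1,2-thiazol-5-yl, and compound 1 and compound 4 differ beyond the scatter even though the groups that leave and enter match in their counts of heavy atoms and hydrogen-bond acceptors. No measurement at hand accounts for the lower maximal response of compound 4.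

The compounds shown leave open whether the lower number goes with the 1,2-thiazole ring itself or with its methyl group, a question that the plain 1,2-thiazol-5-yl group would address. They also leave open how a ring bearing an amine or a carboxylic acid in place of that methyl group would read in this assay on this shared core.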